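Ring-nitrogen chain variation in a rat whole-animal series

The source may report more compounds than this note shows. Statements on the series, on what has been measured and on what is new or still open speak of the compounds shown alone.

Measured so far:
compound 1, `Nc1nc2ccc(C(F)(F)C(F)(F)F)cc2s1`, 2.5 mg/kg
compound 2, `CCN(CC)C(=O)Cn1c(=N)sc2cc(OC(F)(F)F)ccc21`, 9 mg/kg

In a functional assay on the whole organism with Rattus norvegicus as the target (on this read-out lower numbers stand for an effect already at smaller amounts and higher numbers for an effect only at larger amounts of compound), compound 1 gives 2.5 mg/kg and compound 2 gives 9 mg/kg. Among the measured compounds shown here, compound 2 therefore stands at the higher of the two numbers; the gap to compound 1 is beyond the scatter, and the two structures differ in more than one place, so no single step between them can be read.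

Compound 3, `N=c1sc2cc(OC(F)(F)F)ccc2n1CCS`, has not yet been measured in this assay. It keeps the core of compound 2 and differs from it only in the chain on the ring nitrogen: sulfanylmethyl in place of diethylcarbamoyl on a saturated chain carbon bound to an aromatic nitrogen. What leaves is a diethylcarbamoyl group with one acceptor and no donor; what enters is a sulfanylmethyl group carrying one donor and one acceptor.

For the measured compounds named here, no measured pair shows such an exchange, so the step is open. A change of this kind, on the chain rather than on the aromatic part, is expected to give no step beyond the scatter, a 1.3-fold lower number from compound 2 to compound 3 (0.11 log units; within the scatter), with a slight lean toward a lower number. Compound 3 is estimated at 7 mg/kg, within 2.5 mg/kg to 20 mg/kg.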

Compound 3, dose for half-maximal effect: 2 mg/kg
For compound 3 the middle estimate is 3.5-fold (0.54 log units) above the measured one; measured number below the stated range.
By their numbers in this assay, from the lowest: compounds 3 and 1 (each within the scatter of the next); then compound 2.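

Among the compounds shown here, the chain on the ring nitrogen is not a silent part of the molecule in this assay: sulfanylmethyl in place of diethylcarbamoyl on a saturated chain carbon bound to an aromatic nitrogen gives a 4.5-fold lower number from compound 2 to compound 3 (0.65 log units; beyond the scatter), the first step that can be read. The diethylcarbamoyl group is therefore not required for an effect in the whole animal, since compound 3, with the much smaller sulfanylmethyl group, gives 2 mg/kg. Nothing available explains this step.

As far as these compounds go, this reading rests on a single pair, so it remains open whether the step comes from the loss of diethylcarbamoyl or from the arrival of the sulfur-bearing group, which also brings a hydrogen-bond donor that the leaving group lacks. Hydroxymethyl or aminomethyl at the same place, a smaller amide such as dimethylcarbamoyl, or a longer chain ending in sulfanyl would help separate these two readings and show how far the chain can vary.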